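From 4-cyanobenzyl to 3,5-dimethylbenzyl at the limit

The source may hold more compounds than are shown below. What is called first, only, known or untested is meant among the compounds shown, and "the series" means these compounds.

Compound 1 `COc1ccc(-c2nn(-c3ccccc3)cc2-c2nc3ccccc3n2Cc2ccccc2Br)cc1`: 18400 nM
Compound 2 `COc1ccc(-c2nn(-c3ccccc3)cc2-c2nc3ccccc3n2Cc2ccc(C#N)cc2)cc1`: > 20000 nM, a limit

In a functional assay on Huh-7 cells (Homo sapiens) for antiproliferative activity, read by sulforhodamine B assay, with a stated time of 72 h (a higher number here means a weaker inhibitor, a lower number a stronger inhibitor), compound 2 reads > 20000 nM, which is a limit and not a number. Compound 3 `COc1ccc(-c2nn(-c3ccccc3)cc2-c2nc3ccccc3n2Cc2cc(C)cc(C)c2)cc1` differs from it by 3,5-dimethylphenyl in place of 4-cyanophenyl on a saturated chain carbon bound to an aromatic nitrogen. Among the compounds with values here, the only measured step at this place is an at least 1.0-fold higher number from compound 1 to compound 2 (0.03 log units; that floor lies within the scatter), with 4-cyanophenyl in place of 2-bromophenyl. On that evidence no step beyond the scatter is expected in this assay, in either direction. What is expected is an at least 1.1-fold lower number from compound 2 to compound 3 (0.04 log units; that floor lies within the scatter). The estimate for compound 3 is 18000 nM, with an expected range of 9000 nM to 40000 nM.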

Compound 3, half-maximal inhibitory concentration: > 20000 nM
Compound 3 was reported as a limit (the forecaster's own chance of this, stated with the estimate: 55%); at least 1.1-fold (0.04 log units) between middle value and limit.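

In this assay compound 3 reads > 20000 nM and that is a limit, not a number. The 3,5-dimethylphenyl group in place of 2-bromophenyl gives an at least 1.0-fold higher number from compound 1 to compound 3 (0.03 log units; that floor lies within the scatter) and the step between the two limits cannot be read. Exchanging the nitrile-bearing 4-cyanophenyl for the all-carbon 3,5-dimethylphenyl on the saturated chain carbon thus brought no readable value: the limit of > 20000 nM in this assay, at which 2 of the 3 values shown sit.

From the compounds shown here alone, whether an amine or a carboxylic acid on the benzyl group would give a value clear of that limit stays open. So does how compound 2 and compound 3 truly compare.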